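Compound 3 to compound 4: replacing the butylamino group

The source may hold more compounds than are shown below. What is called first, only, known or untested is meant among the compounds shown, and "the series" means these compounds.

In a functional assay on MCF7 cells (Homo sapiens) for antiproliferative activity, read by MTT assay, with a stated time of 24 h (on this read-out higher numbers stand for weaker inhibition and lower numbers for stronger inhibition), compound 1 `CCCCNC(=O)COc1ccc(C(=O)c2c(CCCC)oc3ccccc23)cc1` gives > 50000 nM, which is a limit and not a number. Among the measured compounds shown here, compound 2 `CCCCc1oc2ccccc2c1C(=O)c1ccc(OCC(=O)N[C@H](C)c2ccccc2)cc1` gives 14100 nM, the only true number so far. Compound 3 `CCCCNC(=O)CCCOc1ccc(C(=O)c2c(CCCC)oc3ccccc23)cc1` gives > 50000 nM, which is also a limit. Compound 3 therefore stands with compound 1 at the limit of > 50000 nM in this assay, at which 2 of the 3 values shown sit.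

The measured steps are few. The first is an at least 3.5-fold lower number from compound 1 to compound 2 (0.54 log units; beyond the scatter), with 1-phenylethyl in place of butyl on an amide-type nitrogen. The second is an at least 3.5-fold higher number from compound 2 to compound 3 (0.54 log units; beyond the scatter), which returns the series to the limit. The third is a step that the two limits leave unreadable from compound 1 to compound 3.

Compound 4 `CCCCc1oc2ccccc2c1C(=O)c1ccc(OCCCC(=O)N2CCOCC2)cc1` differs from compound 3 only on a carbonyl carbon: morpholin-4-yl in place of butylamino on a carbonyl carbon. In words, morpholin-4-yl stands in place of butylamino. For the measured compounds named here, no measured step covers this exact change. The closest evidence is an at least 3.5-fold lower number from compound 1 to compound 2 (0.54 log units; beyond the scatter), the only readable gain, and it came with 1-phenylethyl, a group that compound 4 does not carry. No gain beyond the scatter is therefore expected, and compound 4 will probably stay at the limit of this read-out. The estimated step is a number no higher from compound 3 to compound 4 (the limit leaves the size open). The estimate for compound 4 is 50000 nM, with an expected range of 20000 nM to 100000 nM.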

Compound 4, half-maximal inhibitory concentration: 41200 nM
The estimate for compound 4 lay 1.2-fold (0.08 log units) above the measured number, within the range that was stated.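

In this assay compound 3 stands only as a limit, not a number: the limit of > 50000 nM in this assay, at which 2 of the 4 values shown sit.

Morpholin-4-yl on this carbonyl carbon carries no hydrogen-bond donor where butylamino carries one, and it brings a six-membered ring, yet compound 4 gives a true number at the top of the read-out, though an at least 1.2-fold lower number from compound 3 to compound 4 (0.08 log units; that floor lies within the scatter) and an at least 1.2-fold lower number from compound 1 to compound 4 (0.08 log units; that floor lies within the scatter) rest on floors, so neither supports a gain over the butylamino compounds. Among the compounds shown here, the only step here that is beyond the scatter is a 2.9-fold higher number from compound 2 to compound 4 (0.47 log units; beyond the scatter), which leaves compound 2, with its (1-phenylethyl)carbamoyl group, ahead of compound 4.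

Still open, as far as these compounds go, is how (morpholin-4-yl)carbonyl would read in place of the butylcarbamoyl of compound 1, and how 1-phenylethyl would read on the amide nitrogen of compound 3. The compounds shown also do not tell whether a piperidin-1-yl or a 4-methylpiperazin-1-yl group on the same carbonyl carbon, or a free carboxylic acid at the end of the chain, would read differently from morpholin-4-yl.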